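A few compounds are considered here, and "the series" means these few. Any claim that something is new, unique, unknown or untested is made for them only; others in the source may bear on it.

Compound 3 `COc1cc(/C=C/C(=O)c2cccc(-n3cc(-c4ccccc4)[nH]c3=O)c2)cc(OC)c1OC` gives 1370 nM in a functional assay on KM12 cells (Homo sapiens) for inhibition; on this read-out higher numbers stand for weaker inhibition of growth and lower numbers for stronger inhibition of growth. Among the three measured compounds that number is the second highest; it sits nearest to compound 2 `O=C(/C=C/c1cccc(O)c1)c1cccc(-n2cc(-c3ccc(Cl)cc3)[nH]c2=O)c1`, which gives 1340 nM, and furthest from compound 1 `O=C(/C=C/c1cccc(O)c1)c1cccc(-n2cc(-c3ccccc3)[nH]c2=O)c1`, which gives 1830 nM, yet both gaps stay within the scatter, so the three cannot be ranked against one another. Compound 4 `COc1ccc(-c2cn(-c3cccc(C(=O)/C=C/c4cc(OC)c(OC)c(OC)c4)c3)c(=O)[nH]2)cc1` differs from compound 3 by methoxy in place of hydrogen on an aromatic carbon. Going by the values given here, one measured step bears on this change, a chloro in place of hydrogen on an aromatic carbon of the same ring: a 1.4-fold lower number from compound 1 to compound 2 (0.14 log units; within the scatter). A single step that stays within the scatter gives no reason to expect a methoxy at that place to move the number beyond the scatter in either direction. The expected step from compound 3 to compound 4 is therefore small, a 1.1-fold lower number from compound 3 to compound 4 (0.02 log units; within the scatter). Compound 4 is estimated to give 1300 nM in this assay, with a range from 600 nM to 2900 nM.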

Compound 4, concentration for 50% growth inhibition: 1420 nM
The estimate for compound 4 lay 1.1-fold (0.04 log units) below the measured number; the measured number falls inside the stated range.
By their numbers in this assay, from the lowest: compounds 2, 3, 4 and 1 (each within the scatter of the next).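

In this assay, placing a methoxy on this ring, para to a large group, gives a 1.0-fold higher number from compound 3 to compound 4 (0.02 log units; within the scatter), so the change from phenyl to 4-methoxyphenyl cannot be told apart from repeat-measurement noise. Going by these compounds alone, the only earlier step at this place was a chloro added to compound 1; now a second kind of group, added to a second parent, compound 3, also stays within the scatter. This position has therefore taken two different groups without a readable shift in growth inhibition, and no measurement shown offers an explanation for that.

The compounds shown leave open whether an amine, a carboxylic acid or a longer chain at this place would move the number beyond the scatter. They also leave open whether chloro and methoxy would match on one and the same parent compound.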